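Purine glycinamide amino-acid conjugates in the tail flick test

This account rests on a few compounds, and the source may have more. Where it says the series, first, only, none or still open, it means among the compounds named here.

Three compounds have been examined in a functional assay on the whole organism (Tail, strain ICR) with Mus musculus as the target, in the tail flick test, with a stated time of 60 min, at a dose of 25 umol/kg by the oral route; on this read-out lower numbers stand for a weaker effect and higher numbers for a stronger effect at the one dose given. Compound 1, `CC(C)[C@H](NC(=O)CN(c1nc(Cl)nc2[nH]cnc12)C1CC1)C(=O)O`, gives 38.8%, while compound 2, `CSCC[C@H](NC(=O)CN(c1nc(Cl)nc2[nH]cnc12)C1CC1)C(=O)O`, gives 22.8%. These two differ by isopropyl in place of 2-(methylsulfanyl)ethyl on a saturated chain carbon bound to an amide-type nitrogen and a carbonyl carbon, and the step is a number 16 percentage points higher from compound 2 to compound 1 (beyond the scatter). Compound 3, `CSCC[C@H](NC(=O)CN(c1ncnc2c1ncn2C1CCCCO1)C1CC1)C(=O)OCc1ccccc1`, gives 41%; the difference between its core and the core of compound 2 is not broken down here, since the two differ in more than one place.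

Compound 4, `CC(C)[C@H](NC(=O)CN(c1ncnc2c1ncn2C1CCCCO1)C1CC1)C(=O)OCc1ccccc1`, has not yet been measured in this assay. It is related to compound 3 by isopropyl in place of 2-(methylsulfanyl)ethyl on a saturated chain carbon bound to an amide-type nitrogen and a carbonyl carbon, the same change that leads from compound 2 to compound 1. Because that earlier step was a number 16 percentage points higher from compound 2 to compound 1 (beyond the scatter), a rise in the same direction is expected for compound 4, though compound 3 already stands among the higher numbers, so a somewhat smaller step of a number 10 percentage points higher from compound 3 to compound 4 (within the scatter) is estimated. On that basis compound 4 is expected to give about 51% in this assay, within a range from 36% to 66%.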

Compound 4, a percentage reported as activity, at one dose (the size of the read-out at that dose, not a potency): 34.9%
Compound 4: middle estimate off by 16.1 percentage points, on the high side, outside the stated range (below it).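

In this assay, the exchange of 2-(methylsulfanyl)ethyl for isopropyl gives a number 6.1 percentage points lower from compound 3 to compound 4 (within the scatter), so on this core the change has no effect that can be told from the scatter. The result shows that the change does not carry over from one core to the other in this series with the same outcome, and the two steps disagree by more than repeated measurement would explain: the same change on two cores in this assay, a number 16 percentage points higher (beyond the scatter) from compound 2 to compound 1 and a number 6.1 percentage points lower (within the scatter) from compound 3 to compound 4, 22.1 percentage points apart, beyond the scatter of two such steps. It does not show that the change reverses on the second core, since this step stays within the scatter, and it gives no reason for the disagreement.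

The two cores differ in several places at once, and no pair among the compounds shown isolates any one of those differences, so which of them matters remains open. Also open, going by these compounds, is whether a side chain carrying an amine, or a longer unbranched alkyl chain, would follow either step on these two cores.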